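Removing the amide methyl from a short-linker analogue

This account rests on a few compounds, and the source may have more. Where it says the series, first, only, none or still open, it means among the compounds named here.

Compound 1, `Cn1c(Cc2nn(C)c(=O)c3ccccc23)nnc1SCCCCCCCCCCCCCCCC(=O)Nc1ccc(Cl)cc1Cl`, gives 7300 nM in an assay on isolated protein (Mus musculus) for inhibition of IL15-IL15 receptor (Homo sapiens), read by resazurin assay, with stated times of 30 min and 2.5 days; on this read-out lower numbers stand for stronger inhibition and higher numbers for weaker inhibition.
Compound 2, `CN(C(=O)CSc1nnc(Cc2nn(C)c(=O)c3ccccc23)n1C)c1ccc(Cl)cc1Cl`, is reported in this assay only as a limit, > 30000 nM.
Compound 3, `Cn1c(Cc2nn(C)c(=O)c3ccccc23)nnc1SCCCCCCCC(=O)Nc1ccc(O)cc1`, is likewise reported only as a limit, > 30000 nM.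

Compound 2 thus stands at the limit of > 30000 nM in this assay, at which 2 of the 3 values shown sit, and only compound 1 gives a number. Compound 4, `Cn1c(Cc2nn(C)c(=O)c3ccccc23)nnc1SCC(=O)Nc1ccc(Cl)cc1Cl`, differs from compound 2 by one change, (hydrogen in place of methyl on an amide-type nitrogen), hydrogen in place of methyl on an amide-type nitrogen. No measured pair separates these two forms, so the size of this step in this assay is not known from the shown compounds. Compound 1 carries the amide hydrogen and gives 7300 nM. Compound 3 also carries it yet sits at a limit. Compound 4 is therefore expected to remain weak, with an estimated step of an at least 1.2-fold lower number from compound 2 to compound 4 (0.07 log units; that floor lies within the scatter). The estimate for compound 4 is 25000 nM, between 6000 nM and 60000 nM.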

Compound 4, half-maximal inhibitory concentration: 17300 nM
The estimate for compound 4 lay 1.4-fold (0.16 log units) above the measured number; the range from low to high includes it.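

Hydrogen in place of methyl on the amide-type nitrogen brings this short-linker compound from a limit to a measured number in this assay, the first single change that can be read here: an at least 1.7-fold lower number from compound 2 to compound 4 (0.23 log units; that floor lies within the scatter). The size of the step has only a floor, because compound 2 is reported as a limit: the limit of > 30000 nM in this assay, at which 2 of the 4 values shown sit. The compounds shown leave open how an ethyl group on this nitrogen would read. They also leave open whether a methyl on the amide nitrogen of a longer chain would produce a similar step.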